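Hydroxymethyl addition on the dimethylamino analogue, compound 4

This account rests on a few compounds, and the source may have more. Where it says the series, first, only, none or still open, it means among the compounds named here.

Compound 1 `CN(C)c1ccc(-c2nc3c(s2)C(O)CNC3)cc1` in a functional assay on MCF7 cells (Homo sapiens) for cytotoxicity, read by sulforhodamine B assay, with a stated time of 2 days (on this read-out lower numbers stand for stronger inhibition and higher numbers for weaker inhibition), gives 1600 nM, the highest of the three numbers in hand. Compound 3 `OC1CNCc2nc(-c3ccc(N4CCCC4)cc3)sc21` gives 1530 nM; the step of a 1.0-fold lower number from compound 1 to compound 3 (0.02 log units; within the scatter) lies within the scatter. For the measured compounds named here, compound 2 `OCc1cc(N2CCCC2)ccc1-c1nc2c(s1)C(O)CCC2` gives 56 nM, the one number far from compound 1, but compound 2 differs from compound 3 in more than one place, so the part played by its hydroxymethyl cannot be separated out.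

Compound 4 `CN(C)c1ccc(-c2nc3c(s2)C(O)CNC3)c(CO)c1` is compound 1 with hydroxymethyl in place of hydrogen on an aromatic carbon. Going by the values given here, no measured step isolates this change: the only step in hand, from compound 1 to compound 3, touches the amino group and was within the scatter, and the pair compound 3 to compound 2 carries a second change alongside the hydroxymethyl. The values of compound 2 and compound 3 are the sole hint, and they point to a lower number, though with much uncertainty. The step from compound 1 to compound 4 is therefore expected to be a 3.2-fold lower number from compound 1 to compound 4 (0.51 log units; beyond the scatter). Compound 4 is estimated at 500 nM, within a range from 100 nM to 2000 nM.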

Compound 4, half-maximal inhibitory concentration: 31 nM
The estimate for compound 4 lay 16-fold (1.21 log units) above the measured number; the whole stated range lies above it.
By their numbers in this assay, from the lowest: compounds 4 and 2 (each within the scatter of the next); then compounds 3 and 1 (each within the scatter of the next).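

In this assay, for the compounds shown here, hydroxymethyl in place of hydrogen on an aromatic carbon, ortho to a large group and meta to a dimethylamino group, gives a 52-fold lower number from compound 1 to compound 4 (1.71 log units; beyond the scatter), and this is the only step in hand that isolates the change. This position on the core of compound 1 is therefore highly sensitive to substitution, whereas the amino group exchange gave a 1.0-fold lower number from compound 1 to compound 3 (0.02 log units; within the scatter), which lies within the scatter. Nothing measured here accounts for the size of the hydroxymethyl step.

On these data alone, whether this step is particular to hydroxymethyl stays open, since a methyl, a methoxymethyl, an aminomethyl or a carboxylic acid on the same carbon would be needed to tell. Also open, as far as these compounds go, is whether hydroxymethyl on compound 3 would give a step of similar size.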